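Phenyl for pyridin-2-yl: the exposure of compound 3

A few compounds are considered here, and "the series" means these few. Any claim that something is new, unique, unknown or untested is made for them only; others in the source may bear on it.

Within the data shown here, compound 1 `CC(Sc1nc2c(cnn2C)c(=O)n1-c1ccccc1)c1ccccn1` gives 2870 ng.h/mL in an ADME assay on the whole organism (Mus musculus, strain CD-1) for pharmacokinetics, read by LC-MS, with a stated time of 7 h, at a dose of 10 mg/kg by the intraperitoneal route (a lower number here means less compound in the circulation, a higher number more compound in the circulation at the dose given), the lower of the two numbers known so far. Among the measured compounds shown here, compound 2 `CC(Sc1nc2nn(C3(C)COC3)cc2c(=O)n1-c1ccccc1)c1ccccc1` gives 9630 ng.h/mL in this assay, a gap beyond the usual scatter; the two compounds differ in more than one place, so no single step joins them. Compound 3 `CC(Sc1nc2c(cnn2C)c(=O)n1-c1ccccc1)c1ccccc1` awaits measurement and differs from compound 1 in one place: phenyl in place of pyridin-2-yl on a saturated chain carbon bound to a saturated chain carbon and a sulfur. For the measured compounds named here, no measured pair shows this change alone, so the step is expected to be modest in either direction, a 1.2-fold higher number from compound 1 to compound 3 (0.09 log units; within the scatter). Compound 3 is therefore estimated at 3500 ng.h/mL, within a range from 1200 ng.h/mL to 10000 ng.h/mL.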

Compound 3, area under the concentration-time curve: 1780 ng.h/mL
The estimate for compound 3 lay 2.0-fold (0.29 log units) above the measured number; measured number inside the range.
By their numbers in this assay, from the lowest: compounds 3 and 1 (each within the scatter of the next); then compound 2.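

In this assay, placing phenyl where pyridin-2-yl stood on a saturated chain carbon bound to a saturated chain carbon and a sulfur gives a 1.6-fold lower number from compound 1 to compound 3 (0.21 log units; within the scatter). Among these compounds, this is the first single change that can be read at this position, and with the ring nitrogen and its hydrogen-bond acceptor gone, the step stays within the scatter. Nothing measured here gives a reason for the size of this step.

On these data alone, whether an amine or a carboxylic acid at this position would move the number beyond the scatter stays open. So does whether the same change gives a similar step on the core of compound 2.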